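The compounds below may be only part of what the source reports. "The series", "measured", "known", "first", "only" and "open" are said of these compounds alone.

The three measured compounds share one core, seen in compound 1 `CCc1ccc(C(=O)/C=C/C(=O)O)cc1`, which in a functional assay on HeLa cells (Homo sapiens) for inhibition, read by MTT assay, with a stated time of 72 h (on this read-out lower numbers stand for stronger inhibition and higher numbers for weaker inhibition), gives 27800 nM. Among the three numbers this places compound 1 second highest. Nearest to it stands compound 2 `COc1ccc(C(=O)/C=C/C(=O)O)c(OC)c1OC`, which in this assay gives 96200 nM, a higher number beyond the scatter. Furthest away stands compound 3 `O=C(O)/C=C/C(=O)c1cc(C2CCCCC2)ccc1C1CCCCC1`, which in this assay gives 1260 nM, a lower number well beyond the scatter. No two of these compounds differ in one place only, so no single step has been measured, and the differences between them involve several changes at once.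

Compound 4 `CC(C)c1ccc(C(=O)/C=C/C(=O)O)cc1` has not yet been measured. It differs from compound 1 by methyl in place of hydrogen on a saturated chain carbon bound to an aromatic carbon and a saturated chain carbon; cut one bond further out, the same difference reads ethyl to isopropyl. Within the data shown here, with no measured step to lean on, the expected step of a 1.5-fold lower number from compound 1 to compound 4 (0.19 log units; within the scatter) is small, toward a lower number, and within the scatter. Compound 4 is thus expected to give an estimated 18000 nM, with a range from 7000 nM to 45000 nM.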

Compound 4, half-maximal inhibitory concentration: 4900 nM
Beside the measured number, compound 4's estimate is 3.7-fold (0.57 log units) above it; the measured number lies below the stated range.
By their numbers in this assay, from the lowest: compound 3; then compound 4; then compound 1; then compound 2.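

Among these compounds, the step from ethyl to isopropyl is the first single change that can be read in this set: in this assay it gives a 5.7-fold lower number from compound 1 to compound 4 (0.75 log units; beyond the scatter), a shift beyond the scatter. It shows that this saturated chain carbon, bound to an aromatic carbon and a saturated chain carbon, is not indifferent to substitution, since a methyl in place of hydrogen moves the number even though it brings no ring, no hydrogen-bond donor or acceptor and no net charge. Nothing available explains why the number moves at this position.

The compounds shown leave open how a tert-butyl group, a cyclopropyl ring or a longer chain would read at this place. They also leave open whether a hydroxyl or an amine on this same carbon would keep the lower number.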